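Notes on a thiosemicarbazone series, antiproliferative read-out

The source may report more compounds than this note shows. Statements on the series, on what has been measured and on what is new or still open speak of the compounds shown alone.

Measured compounds:
compound 1, `Cc1ccc(NC2=C/C(=N/NC(N)=S)C(=O)N=C2Nc2ccc(C)cc2)cc1`, 3060 nM
compound 2, `NC(=S)N/N=C1/C=C(Nc2ccc(F)cc2)C(Nc2ccc(F)cc2)=NC1=O`, 1120 nM
compound 3, `NC(=S)N/N=C1/C=C(Nc2cccc([N+](=O)[O-])c2)C(Nc2cccc([N+](=O)[O-])c2)=NC1=O`, 11100 nM

All three were run in a functional assay on MCF7 cells (Homo sapiens) for antiproliferative activity, read by MTT assay, with a stated time of 72 h; on this read-out lower numbers stand for stronger inhibition and higher numbers for weaker inhibition. Compound 2 gives the lowest number of the three: compound 1 sits at a number that is beyond the scatter above it, and compound 3 further still, also beyond the scatter. For the measured compounds named here, the three differ from one another in the substituents on the two anilines of the shared core and in nothing else, so no single-point step between measured compounds is available, and the two gaps are only described by what their values show.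

Compound 4, `N/C(=N\N=C1\C=C(Nc2ccc(F)cc2)C(Nc2ccc(F)cc2)=NC1=O)SCc1ccccc1`, starts from compound 2 and changes the side chain rather than the anilines: a group of 11 heavy atoms (8 carbon, 2 nitrogen, 1 sulfur; one six-membered aromatic ring of carbon only) in place of a group of 4 heavy atoms (1 carbon, 2 nitrogen, 1 sulfur; no ring), on a double-bonded nitrogen. The core and both fluorinated anilines are kept. Going by the values given here, no measured pair in this set varies that position, so there is nothing here to set the direction or size of the step. The expectation is therefore for a step that does not clear the scatter in this assay, and the estimated step is a 1.3-fold higher number from compound 2 to compound 4 (0.13 log units; within the scatter).

On that basis compound 4 is estimated at 1500 nM, with a range from 400 nM to 6000 nM, the width reflecting the absence of any comparable change among the measured compounds.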

Compound 4, half-maximal inhibitory concentration: 7580 nM
Compound 4: the middle estimate sits 5.1-fold (0.70 log units) below what was measured, outside the stated range (above it).
By their numbers in this assay, from the lowest: compound 2; then compound 1; then compounds 4 and 3 (each within the scatter of the next).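

In this assay, putting the group of 11 heavy atoms with its six-membered aromatic ring of carbon only in place of the group of 4 heavy atoms, on a double-bonded nitrogen, with the shared core and both fluorinated anilines kept, gives a 6.8-fold higher number from compound 2 to compound 4 (0.83 log units; beyond the scatter). For the compounds shown here, this is the only single-place step so far, and it shows that the number responds to this position as well as to the anilines, with weaker inhibition after this change and a size beyond the scatter. Nothing at hand bears on what lies behind the step.

A single step gives direction and size for this one replacement only, so the compounds shown leave open whether a group with a methyl or a carboxylic acid in place of the six-membered aromatic ring would move the number as far. They also leave open whether the same replacement gives a step of like size when the anilines carry methyl or nitro groups instead of fluorine.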